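Swapping the benzothiazole ether for a pyridine ether

This account rests on a few compounds, and the source may have more. Where it says the series, first, only, none or still open, it means among the compounds named here.

Of the compounds shown here, two have been read so far in a functional assay (blood) for inhibition, with Homo sapiens as the target; on this read-out higher numbers stand for weaker inhibition and lower numbers for stronger inhibition. Compound 1 (`CC(C)(C)Sc1c(CC(C)(C)C(=O)O)n(Cc2ccc(Cl)cc2)c2ccc(CCc3ccc4ccccc4n3)cc12`) reads > 3000 nM, which is a limit of the assay and not a number. Among the measured compounds shown here, compound 2 (`COc1ccc2nc(COc3ccc4c(c3)c(SC(C)(C)C)c(CC(C)(C)C(=O)O)n4Cc3ccc(Cl)cc3)sc2c1`) gives 670 nM, the only actual number available.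

The next compound to be read is compound 3 (`CC(C)(C)Sc1c(CC(C)(C)C(=O)O)n(Cc2ccc(Cl)cc2)c2ccc(OCc3cccnc3)cc12`), which carries pyridin-3-yl in place of 6-methoxy-1,3-benzothiazol-2-yl on a saturated chain carbon bound to an oxygen on an aromatic ring. The shared core, the chlorobenzyl group and the acid chain stay as they are.

For the measured compounds named here, no measured step covers this exchange, so the expectation rests on the structural change alone, with compound 2 at 670 nM as the starting point. The entering group is the smaller of the two, and a moderate loss is expected, with the estimated step being a 2.2-fold higher number from compound 2 to compound 3 (0.35 log units; beyond the scatter). For compound 3 the estimated value in this assay is 1500 nM, with an expected range from 400 nM to 5500 nM.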

Compound 3, half-maximal inhibitory concentration: > 3000 nM
Compound 3 gave a limit, no number; the forecaster's own chance of this, stated with the estimate: 35%; middle value at least 2.0-fold (0.30 log units) away from the limit.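

In this assay, among the compounds shown here, pyridin-3-yl in place of 6-methoxy-1,3-benzothiazol-2-yl on a saturated chain carbon bound to an oxygen on an aromatic ring gives an at least 4.4-fold higher number from compound 2 to compound 3 (0.65 log units; beyond the scatter) and is the first readable step. It shows that the number at this place depends on the group carried there: the 6 heavy atoms of pyridin-3-yl do not keep what compound 2 reads with the 11 heavy atoms of 6-methoxy-1,3-benzothiazol-2-yl. Compound 3 reads > 3000 nM, which is a limit and not a number, so this step has a floor but no full size.

As far as these compounds go, how far compound 3 lies past compound 2 stays unknown, and the step between compound 1 and compound 3 cannot be read, because both compounds sit at the same limit: the limit of > 3000 nM in this assay, at which 2 of the 3 values shown sit. Also open, from the compounds shown here alone, is what 1,3-benzothiazol-2-yl without the methoxy, or pyridin-3-yl carrying an amine, would read at this place, so the part of the larger group that the number depends on is not settled.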